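The compounds below may be only part of what the source reports. "The series", "measured", "known", "first", "only" and "open" are said of these compounds alone.

Measured in an ADME assay on BV-2 cells (Mus musculus) for cytotoxicity, with a stated time of 24 h, tested at 50 uM; on this read-out lower numbers stand for a stronger effect and higher numbers for a weaker effect at the one concentration tested:
Compound 1, `COc1cccc(S(=O)(=O)/C=C/c2cccnc2)c1`, gives 90.8%.
Compound 2, `COc1ccc(S(=O)(=O)/C=C/c2cccnc2)cc1`, gives 85.8%.
Compound 3, `COc1cccc(S(=O)(=O)/C=C/c2ccncc2)c1`, gives 21.3%.

Compound 1 and compound 2 share a common layout, but the difference between their two cores is not broken down here; their readings in this assay lie within the usual scatter of each other. Compound 3 arises from compound 1 by a single change, (pyridin-4-yl in place of pyridin-3-yl on a double-bonded chain carbon bound to a double-bonded chain carbon), and that change produces a number 69.5 percentage points lower from compound 1 to compound 3 (beyond the scatter), a large step well beyond the scatter.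

Compound 4, `COc1ccc(S(=O)(=O)/C=C/c2ccncc2)cc1`, has not yet been measured in this assay. It stands to compound 2 exactly as compound 3 stands to compound 1: the change is pyridin-4-yl in place of pyridin-3-yl on a double-bonded chain carbon bound to a double-bonded chain carbon, the same change at the same place. Among the measured compounds shown here, only one example of this change has been measured, so any expectation for compound 4 rests on that single step, a number 69.5 percentage points lower from compound 1 to compound 3 (beyond the scatter). Set beside it, the expected step is a number 63.8 percentage points lower from compound 2 to compound 4 (beyond the scatter), assuming the change carries over from the core of compound 1 to the core of compound 2. On this basis, the reading of compound 4 in this assay is estimated at 22%, with a likely range from 8% to 45%.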

Compound 4, a percentage reported as activity, at one concentration (the size of the read-out at that concentration, not a potency): 69%
Beside the measured number, compound 4's estimate is 47 percentage points below it; the whole stated range lies below it.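

In this assay, pyridin-4-yl in place of pyridin-3-yl gives a number 16.8 percentage points lower from compound 2 to compound 4 (beyond the scatter), so the number falls again, but the size of the earlier step does not return, as the two steps set side by side show: the same change on two cores in this assay, a number 69.5 percentage points lower (beyond the scatter) from compound 1 to compound 3 and a number 16.8 percentage points lower (beyond the scatter) from compound 2 to compound 4, 52.7 percentage points apart, beyond the scatter of two such steps

The direction of the change thus holds on both cores shown, whereas its size does not carry over from the core of compound 1 to the core of compound 2. With only these two pairs, the data do not show what in the cores sets the size of the step, nor what the change would do on any further core.

The compounds shown leave open which difference between the two cores accounts for the gap between the steps. They also leave open whether the step would stay small or large on a core bearing an amine or a carboxylic acid in place of the methoxy group.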